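From Hydroxy to Acetamido on a Sulfonyl Sulfur

The source may hold more compounds than are shown below. What is called first, only, known or untested is meant among the compounds shown, and "the series" means these compounds.

In a physicochemical assay for solubility, at pH 4 (a higher number here means that the compound lasts longer, a lower number that the compound disappears faster), compound 1 `CC(C)(CS(=O)(=O)O)N(Cl)Cl` gives > 4800 h as a limit of the assay, not a number. Compound 2 `CC(C)(CCS(=O)(=O)O)N(Cl)Cl` gives 4180 h as a measured half-life. Compound 3 `CC(=O)NS(=O)(=O)CC(C)(C)N(Cl)Cl` carries acetamido in place of hydroxy on a sulfonyl sulfur. For the measured compounds named here, no measured step between compounds covers this change, so the expectation is uncertain. In this assay a moderate fall in half-life is expected, the estimated step being an at least 2.4-fold lower number from compound 1 to compound 3 (0.38 log units; beyond the scatter) as a rough guide. Compound 3 is estimated at 2000 h (expected range 500 h to 5000 h).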

Compound 3, half-life: 1060 h
Estimate against measurement, compound 3: 1.9-fold (0.28 log units) above; the range from low to high includes it.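

In this assay, for the compounds shown here, acetamido in place of hydroxy on a sulfonyl sulfur gives an at least 4.5-fold lower number from compound 1 to compound 3 (0.65 log units; beyond the scatter) and so shows that the half-life responds to a change at this position, which the earlier compounds, differing only in their chain, did not show. The step has an open end because compound 1 stands at a limit of the assay, not at a number: the limit of > 4800 h in this assay, at which 1 of the 3 values shown sits.

As far as these compounds go, it remains open whether a plain amino group or a methoxy group on the same sulfonyl sulfur would lower the half-life as far. From the compounds shown here alone, it also remains open whether acetamido would do the same on the longer chain of compound 2.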